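The source may hold more compounds than are shown below. What is called first, only, known or untested is meant among the compounds shown, and "the series" means these compounds.

In an assay on CHO cells for binding affinity to metabotropic glutamate receptor 2 (Rattus norvegicus) (on this read-out higher numbers stand for weaker inhibition and lower numbers for stronger inhibition), the measured compounds are:
compound 1, `N[C@]1(C(=O)O)[C@H]2[C@@H](C[C@H]1OCc1cccc(Cl)c1)[C@]2(F)C(=O)O`, 3.28 nM
compound 2, `N[C@]1(C(=O)O)[C@H]2[C@@H](C[C@H]1OCc1cccc(C(F)(F)F)c1)[C@]2(F)C(=O)O`, 5.72 nM
compound 3, `N[C@]1(C(=O)O)[C@H]2[C@@H](C[C@H]1OCc1cccc(Oc3ccccc3)c1)[C@]2(F)C(=O)O`, 7.15 nM

Compound 1 gives the lowest of the three numbers. Compound 2 sits at a 1.7-fold higher number from compound 1 to compound 2 (0.24 log units; within the scatter), which stays within the scatter, and compound 3 at a 2.2-fold higher number from compound 1 to compound 3 (0.34 log units; beyond the scatter), a modest step beyond it. Between compound 2 and compound 3 the gap is a 1.3-fold higher number from compound 2 to compound 3 (0.10 log units; within the scatter). Compound 4, `N[C@]1(C(=O)O)[C@H]2[C@@H](C[C@H]1OCc1cccc(F)c1F)[C@]2(F)C(=O)O`, differs from compound 1 by 2,3-difluorophenyl in place of 3-chlorophenyl on a saturated chain carbon bound to an oxygen on a saturated carbon. Within the data shown here, no measured step puts fluorine on this ring, so the steps that bear on the change are the two exchanges of the chloro group, for trifluoromethyl in a 1.7-fold higher number from compound 1 to compound 2 (0.24 log units; within the scatter) and for phenoxy in a 2.2-fold higher number from compound 1 to compound 3 (0.34 log units; beyond the scatter); both leave the number close to that of compound 1. On that basis compound 4 is expected to stay near compound 1, with an expected step of a 1.4-fold higher number from compound 1 to compound 4 (0.14 log units; within the scatter) that does not clearly exceed the scatter. For compound 4 the estimate in this assay is 4.5 nM, with a range from 2 nM to 10 nM.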

Compound 4, inhibition constant: 4.25 nM
The estimate for compound 4 lay 1.1-fold (0.02 log units) above the measured number, within the range that was stated.
By their numbers in this assay, from the lowest: compounds 1, 4, 2 and 3 (each within the scatter of the next, the first and the last beyond it).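

In this assay, 2,3-difluorophenyl in place of 3-chlorophenyl on a saturated chain carbon bound to an oxygen on a saturated carbon gives a 1.3-fold higher number from compound 1 to compound 4 (0.11 log units; within the scatter). The earlier compounds shown here all varied a single group on the ring, whereas compound 4 shows that this position also accepts a ring with 2 fluorine atoms and no chlorine, with a step that stays within the scatter. Nothing available bears on why the number stays so close, so the result remains an observation without an explanation.

The compounds shown leave open what each fluorine contributes, since neither 2-fluorophenyl nor 3-fluorophenyl appears among them. They also leave open how the number would respond to an amine or a carboxylic acid on the ring, or to a longer chain leading to it.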